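The source may report more compounds than this note shows. Statements on the series, on what has been measured and on what is new or still open speak of the compounds shown alone.

In a functional assay on MCF7 cells (Homo sapiens) for antiproliferative activity, read by MTT assay (on this read-out higher numbers stand for weaker inhibition and lower numbers for stronger inhibition), compound 3 `COc1ccc([C@@H]2[C@@H](C(=O)c3cccs3)C(=O)N2c2cc(OC)c(OC)c(OC)c2)cc1` gives 950 nM. Among the three measured compounds it holds the second highest number: compound 1 `COc1ccc([C@@H]2C(c3cc4ccccc4n3C)C(=O)N2c2cc(OC)c(OC)c(OC)c2)cc1`, with 6600 nM, lies nearest, and compound 2 `COc1ccc([C@@H]2C(c3ccsc3)C(=O)N2c2cc(OC)c(OC)c(OC)c2)cc1`, with 60 nM, lies furthest. Compound 4 `COc1ccc([C@@H]2[C@@H](C(O)c3cccs3)C(=O)N2c2cc(OC)c(OC)c(OC)c2)cc1` differs from compound 3 in one place: hydroxy(thiophen-2-yl)methyl in place of (thiophen-2-yl)carbonyl on a saturated ring carbon. Among the measured compounds shown here, the only measured step, a 110-fold lower number from compound 1 to compound 2 (2.04 log units; beyond the scatter), swaps one aromatic ring for another on that saturated ring carbon; no measured pair shows the carbonyl being reduced to the hydroxy-bearing carbon. That step therefore offers little guidance here, and for compound 4 a step of a 1.1-fold higher number from compound 3 to compound 4 (0.02 log units; within the scatter) is expected, a change not clearly beyond the scatter. Compound 4 is estimated at 1000 nM, with a plausible range from 300 nM to 3500 nM.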

Compound 4, half-maximal inhibitory concentration: 1200 nM
Compound 4: the middle estimate sits 1.2-fold (0.08 log units) below what was measured; low and high end bracket the measured number.
By their numbers in this assay, from the lowest: compound 2; then compounds 3 and 4 (each within the scatter of the next); then compound 1.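

In this assay the swap gives a 1.3-fold higher number from compound 3 to compound 4 (0.10 log units; within the scatter) and so shows no measurable difference between (thiophen-2-yl)carbonyl and hydroxy(thiophen-2-yl)methyl on this saturated ring carbon. At this position, then, the carbonyl can be exchanged for the hydroxy-bearing carbon, which adds a hydrogen-bond donor, without moving the number beyond the scatter. Nothing available here explains why the number holds.
Still open, as far as these compounds go, is whether an amine or a methoxy group in place of the hydroxy group would leave the number just as unchanged. A longer chain between this ring carbon and the thiophene is equally untested in the compounds shown.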